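Isobutylamino Analogue of Compound 1: Cytotoxicity Outlook

The source may hold more compounds than are shown below. What is called first, only, known or untested is meant among the compounds shown, and "the series" means these compounds.

Compound 1 `C[C@H](NC(=O)[C@@]1(Cc2ccccc2)CCN1C(=O)OCc1ccccc1)C(=O)N(C)C` in an ADME assay on HELF cells (Homo sapiens) for cytotoxicity, with a stated time of 3 days; on this read-out lower numbers stand for higher toxicity in this test and higher numbers for lower toxicity in this test: > 100000 nM, a limit of the assay.
Compound 2 `C[C@H](NC(=O)[C@]1(Cc2ccccc2)CCN1C(=O)OCc1ccccc1)C(=O)NC(C)(C)C` in this assay: > 100000 nM, a limit of the assay.
Compound 3 `C[C@H](NC(=O)[C@]1(Cc2ccccc2)CCN1C(=O)OCc1ccccc1)C(=O)N(C)C` in this assay: > 100000 nM, a limit of the assay.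

In this assay compound 1 stands only at a limit, and the two further values shown are limits as well. Compound 4 `CC(C)CNC(=O)[C@H](C)NC(=O)[C@@]1(Cc2ccccc2)CCN1C(=O)OCc1ccccc1` differs from compound 1 by isobutylamino in place of dimethylamino on a carbonyl carbon. Going by the values given here, two measured steps bear on this change: a step that the two limits leave unreadable from compound 2 to compound 3, which alters the group on the same carbonyl carbon, and a step that the two limits leave unreadable from compound 1 to compound 3. Both are unreadable because of the limit of > 100000 nM in this assay, at which 3 of the 3 values shown sit. Neither step gives a size or a direction, so no step beyond the scatter can be read from the data. Compound 4 is therefore expected to sit at the limit again, with an estimated step that the limit leaves unreadable from compound 1 to compound 4. The estimate for compound 4 is 150000 nM, between 50000 nM and 500000 nM.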

Compound 4, half-maximal cytotoxic concentration: > 100000 nM
Compound 4 was reported as a limit; the forecaster's own chance of this, stated with the estimate: 85%; the middle value is on the limit's open side.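

In this assay compound 1 and compound 4 both stand only at a limit of the assay, so no step can be read between them: the limit of > 100000 nM in this assay, at which 4 of the 4 values shown sit.

The compounds shown leave open whether isobutylamino and dimethylamino on this carbonyl carbon differ in cytotoxicity at all.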